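A few compounds are considered here, and "the series" means these few. Any claim that something is new, unique, unknown or untested is made for them only; others in the source may bear on it.

Measured so far in a functional assay on DLD-1 cells (Homo sapiens) for cytotoxicity, read by MTT assay; on this read-out higher numbers stand for weaker inhibition and lower numbers for stronger inhibition:

- Compound 1 `COc1cc(/C=C/C(=O)C(=Cc2ccc(OC)c(OC)c2)C(=O)/C=C/c2ccc(O)c(OC)c2)ccc1O` gives 3070 nM
- Compound 2 `COc1cc(/C=C/C(=O)C(=Cc2ccc(O)cc2)C(=O)/C=C/c2ccc(O)c(OC)c2)ccc1O` gives 4080 nM
- Compound 3 `CCOc1cc(/C=C/C(=O)C(=Cc2ccc(O)c(OC)c2)C(=O)/C=C/c2ccc(O)c(OCC)c2)ccc1O` gives 9630 nM

Compound 3 has the highest number of these three, beyond the scatter from both others, so it inhibits most weakly here. Compound 4 `CCOc1cc(C=C(C(=O)/C=C/c2ccc(O)c(OCC)c2)C(=O)/C=C/c2ccc(O)c(OCC)c2)ccc1O` differs from it by one small change, (methyl in place of hydrogen on a saturated chain carbon bound to an oxygen on an aromatic ring), which turns methoxy into ethoxy: methyl in place of hydrogen on a saturated chain carbon bound to an oxygen on an aromatic ring. Within the data shown here, only one measured step changes a single place, a 1.3-fold higher number from compound 1 to compound 2 (0.12 log units; within the scatter), and that swap of 3,4-dimethoxyphenyl for 4-hydroxyphenyl is a larger edit, yet it stays within the scatter. This evidence is indirect, but no step beyond the scatter is expected in this assay. The estimated step is a 1.1-fold lower number from compound 3 to compound 4 (0.03 log units; within the scatter) and remains small. Compound 4 is expected at 9000 nM, with an estimated range of 4000 nM to 20000 nM.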

Compound 4, half-maximal inhibitory concentration: 1360 nM
The estimate for compound 4 lay 6.6-fold (0.82 log units) above the measured number, outside the stated range (below it).
By their numbers in this assay, from the lowest: compound 4; then compounds 1 and 2 (each within the scatter of the next); then compound 3.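

In this assay there is a 7.1-fold lower number from compound 3 to compound 4 (0.85 log units; beyond the scatter) for one added methyl, so this position responds to a small change, turning methoxy into ethoxy. Among these compounds, the only earlier single-place step, a 1.3-fold higher number from compound 1 to compound 2 (0.12 log units; within the scatter), was a larger edit yet stayed within the scatter, so the size of an edit does not track the size of the step in these compounds. No available evidence accounts for this stronger inhibition.

On these data alone, whether a longer chain, such as propyl, would lower the number further or raise it again remains open.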